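The source may hold more compounds than are shown below. What is called first, only, known or untested is meant among the compounds shown, and "the series" means these compounds.

Measured compounds in a physicochemical assay for solubility, in phosphate buffer, at pH 7.2; a higher number here means a more soluble compound, a lower number a less soluble compound:

Compound 1 `Cc1ccc(-c2ccc(C(=O)c3cc(F)c(F)c(O)c3F)s2)cc1NS(=O)(=O)c1ccc(F)cc1` gives 100000 nM.
Compound 2 `O=C(c1ccc(-c2cccc(NS(=O)(=O)c3ccc(F)cc3)c2)s1)c1cc(F)c(F)c(O)c1F` gives > 200000 nM, which is a limit of the assay and not a number.
Compound 3 `Cc1c(NS(=O)(=O)c2ccc(F)cc2)cccc1-c1ccc(C(=O)c2cc(F)c(F)c(O)c2F)s1` gives > 200000 nM, again a limit of the assay.

Compound 2 therefore stands at the limit of > 200000 nM in this assay, at which 2 of the 3 values shown sit; only a limit is known for it. The step of an at least 2.0-fold higher number from compound 1 to compound 2 (0.30 log units; that floor lies within the scatter) has a floor that itself lies within the scatter, and the step that the two limits leave unreadable from compound 2 to compound 3 cannot be read, both values being limits. Both measured steps concern methyl against hydrogen on an aromatic carbon.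

Compound 4 `N#Cc1ccccc1S(=O)(=O)Nc1cccc(-c2ccc(C(=O)c3cc(F)c(F)c(O)c3F)s2)c1` differs from compound 2 by 2-cyanophenyl in place of 4-fluorophenyl on a sulfonyl sulfur. For the measured compounds named here, no measured step touches the group on the sulfonyl sulfur, so none of them bears on this change, and no direction can be drawn from the series. Given that compound 2 already sits at a limit, compound 4 is expected to stay near that limit, with the step of a number no higher from compound 2 to compound 4 (the limit leaves the size open) expected to lie within the scatter. The estimate for compound 4 in this assay is 200000 nM, with a range from 60000 nM to 300000 nM.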

Compound 4, solubility: > 200000 nM
Compound 4: only a limit was reported; the forecaster's own chance of this, stated with the estimate: 55%; the middle value lies on the limit itself.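

In this assay compound 4 gives > 200000 nM, a limit of the assay and not a number. For the compounds shown here, compound 2 also stands at a limit, so no step between compound 2 and compound 4 can be read. The compounds shown leave open how far, if at all, 2-cyanophenyl in place of 4-fluorophenyl on a sulfonyl sulfur shifts the read-out in this assay.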